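A few compounds are considered here, and "the series" means these few. Any claim that something is new, unique, unknown or untested is made for them only; others in the source may bear on it.

Compound 1 `CCOC(=O)c1c(-c2cccc(Oc3ccccc3)c2)[nH]c2cc(OC)ccc2c1=O`: > 21500 nM, a limit
Compound 2 `CCOC(=O)c1c(-c2cccc(Oc3ccccc3)c2)[nH]c2cc(OC)c(Cl)cc2c1=O`: > 21500 nM, a limit
Compound 3 `CCOC(=O)c1c(-c2cccc(-c3ccccc3)c2)[nH]c2cc(OC)c(F)cc2c1=O`: > 21500 nM, a limit

All three entries come from an ADME assay on BJ cells (Homo sapiens) for cytotoxicity, read by luminescence, with a stated time of 72 h (on this read-out lower numbers stand for an effect already at smaller amounts and higher numbers for an effect only at larger amounts of compound), and the limit of > 21500 nM in this assay, at which 3 of the 3 values shown sit, is the only level seen so far. Compound 3 therefore stands at a limit and not at a number. Compound 4 `CCOC(=O)c1c(-c2cccc(Oc3ccccc3)c2)[nH]c2cc(OC)c(F)cc2c1=O` differs from it as follows: phenoxy in place of phenyl on an aromatic carbon. Among the measured compounds shown here, the only measured step, a step that the two limits leave unreadable from compound 1 to compound 2, concerns another position and gives no size to carry over. Compound 2 already bears phenoxy, and its value of > 21500 nM is a limit. No step beyond the scatter is therefore expected in this assay, and the expected change is a step that the limit leaves unreadable from compound 3 to compound 4. Compound 4 is expected at 25000 nM, with an estimated range of 15000 nM to 40000 nM, and most likely again as a limit.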

Compound 4, half-maximal effective concentration: > 21500 nM
Compound 4 gave a limit, no number; the forecaster's own chance of this, stated with the estimate: 85%; the middle value does not contradict the limit.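

In this assay compound 4 gives > 21500 nM, a limit. Its steps from compound 1, compound 2 and compound 3 cannot be read. The compounds shown leave open at what concentration any of them acts in this assay, and whether phenoxy or phenyl, chloro or fluoro changes that.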